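Urea aryl exchange on the shared core, toward compound 3

A few compounds are considered here, and "the series" means these few. Any claim that something is new, unique, unknown or untested is made for them only; others in the source may bear on it.

Measured compounds in a functional assay on PC-3 cells (Homo sapiens) for antiproliferative activity, read by MTT assay, with a stated time of 48 h; on this read-out lower numbers stand for stronger inhibition and higher numbers for weaker inhibition:
compound 1, `Cc1cccc(NC(=O)Nc2nnc(Sc3ncnc4scc(-c5ccncc5)c34)s2)c1`, gives 5200 nM.
compound 2, `Cc1ccc(NC(=O)Nc2nnc(Sc3ncnc4scc(-c5ccncc5)c34)s2)cc1Cl`, gives 4700 nM.

Compound 1 and compound 2 sit together on these numbers: the step of a 1.1-fold lower number from compound 1 to compound 2 (0.04 log units; within the scatter) is within the scatter, so neither stands apart from the other. Compound 3, `O=C(Nc1ccc(Cl)c(Cl)c1)Nc1nnc(Sc2ncnc3scc(-c4ccncc4)c23)s1`, is not yet measured. It differs from compound 1 as follows: 3,4-dichlorophenyl in place of 3-methylphenyl on an amide-type nitrogen. Among the measured compounds shown here, the one measured step that bears on this is the exchange of 3-methylphenyl for 3-chloro-4-methylphenyl on the same amide-type nitrogen, a 1.1-fold lower number from compound 1 to compound 2 (0.04 log units; within the scatter), which stayed within the scatter. A second aryl change at that position therefore gives no ground to expect a step beyond the scatter in this assay, in either direction. For compound 3 the expected step is a 1.2-fold lower number from compound 1 to compound 3 (0.06 log units; within the scatter). Compound 3 is therefore estimated at 4500 nM, with a range from 2000 nM to 10000 nM.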

Compound 3, half-maximal inhibitory concentration: 3600 nM
Beside the measured number, compound 3's estimate is 1.3-fold (0.10 log units) above it, within the range that was stated.
By their numbers in this assay, from the lowest: compounds 3, 2 and 1 (each within the scatter of the next).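

In this assay, 3,4-dichlorophenyl in place of 3-methylphenyl on the amide-type nitrogen gives a 1.4-fold lower number from compound 1 to compound 3 (0.16 log units; within the scatter), and chloro in place of methyl on an aromatic carbon gives a 1.3-fold lower number from compound 2 to compound 3 (0.12 log units; within the scatter). This position has now taken an aryl group with two chloro substituents and no methyl, and compound 1, compound 2 and compound 3 still cannot be separated on these numbers. No measurement at hand accounts for these numbers or ties them to any property of the groups.

From the compounds shown here alone, all three aryl groups carry only methyl or chloro, so it remains open whether an amine or a carboxylic acid on this ring would give a step beyond the scatter. Going by these compounds, whether a longer alkyl chain could replace the aryl group on this nitrogen also remains open.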